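Swapping a methoxy for a nitro on the benzamide ring

A few compounds are considered here, and "the series" means these few. Any claim that something is new, unique, unknown or untested is made for them only; others in the source may bear on it.

Three compounds share one core and differ only in the group on the outer aromatic ring of the benzamide. Compound 1 `CC(C)(C)c1ccc(C(=O)Nc2cccc(NC(=O)COc3ccc4c(=O)ccoc4c3)c2)cc1` carries a tert-butyl group; in an assay on isolated protein for inhibition of Rho-associated protein kinase 2 (Homo sapiens), read by scintillation counting, radiometric assay and 33P incorporation, with a stated time of 40 min, in the presence of a further agent that is not named here (on this read-out higher numbers stand for weaker inhibition and lower numbers for stronger inhibition), compound 1 gives 34 nM. Compound 2 `O=C(COc1ccc2c(=O)ccoc2c1)Nc1cccc(NC(=O)c2ccc(F)cc2)c1` carries a fluoro group, and compound 2 gives 54 nM. Compound 3 `COc1ccc(C(=O)Nc2cccc(NC(=O)COc3ccc4c(=O)ccoc4c3)c2)cc1` carries a methoxy group, and compound 3 gives 7 nM, the lowest of the three numbers; the steps of a 4.9-fold lower number from compound 1 to compound 3 (0.69 log units; beyond the scatter) and a 7.7-fold lower number from compound 2 to compound 3 (0.89 log units; beyond the scatter) both lie beyond the scatter, whereas a 1.6-fold higher number from compound 1 to compound 2 (0.20 log units; within the scatter) does not.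

Compound 4 `O=C(COc1ccc2c(=O)ccoc2c1)Nc1cccc(NC(=O)c2ccc([N+](=O)[O-])cc2)c1` differs from compound 3 in one place: nitro in place of methoxy on an aromatic carbon. Among the measured compounds shown here, no measured pair shows nitro entering or leaving this ring, so the only guide is that the methoxy of compound 3 gave lower numbers than either tert-butyl or fluoro at the same position. Taking the methoxy away again is therefore expected to move the number back up, with compound 4 estimated at 40 nM, in a range from 12 nM to 130 nM, which means an expected step of a 5.7-fold higher number from compound 3 to compound 4 (0.76 log units; beyond the scatter).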

Compound 4, half-maximal inhibitory concentration: 15 nM
The estimate for compound 4 lay 2.7-fold (0.43 log units) above the measured number; the range from low to high includes it.
By their numbers in this assay, from the lowest: compound 3; then compound 4; then compounds 1 and 2 (each within the scatter of the next).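

Methoxy is not the only group that gives a low number at this place on the ring. Nitro falls short of it, with a 2.1-fold higher number from compound 3 to compound 4 (0.33 log units; beyond the scatter), yet it still gives a lower number than the other two groups, with a 3.6-fold lower number from compound 2 to compound 4 (0.56 log units; beyond the scatter) and a 2.3-fold lower number from compound 1 to compound 4 (0.36 log units; beyond the scatter), so the four groups now form three levels: methoxy, then nitro, then tert-butyl and fluoro, which stay within the scatter of each other. No measurement at hand explains why nitro lands at this level.

As far as these compounds go, how an amine, a carboxylic acid or a longer chain such as ethoxy would rank at this place remains open. So does whether the same ranking of groups would hold if another part of the shared core were changed.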